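This account rests on a few compounds, and the source may have more. Where it says the series, first, only, none or still open, it means among the compounds named here.

Compound 1 `N=C(N)c1ccc(/N=N/Nc2cccc(C#Cc3ccccn3)c2)cc1`: 10700 nM
Compound 2 `COc1ccc(C#Cc2cccc(N/N=N/c3ccc(C(=N)N)cc3)c2)cc1`: 5200 nM
Compound 3 `N=C(N)c1ccc(/N=N/Nc2cccc(C#Cc3ccccc3)c2)cc1`: not yet measured

In a functional assay on OVCAR-3 cells (Homo sapiens) for antiproliferative activity, read by WST assay, with a stated time of 72 h (a lower number here means a stronger inhibitor of growth, a higher number a weaker inhibitor of growth), compound 2 holds the lower of the two numbers, 5200 nM. Compound 3 carries hydrogen in place of the methoxy of compound 2, on an aromatic carbon para to a large group: hydrogen in place of methoxy on an aromatic carbon. Within the data shown here, only one measured step bears on this change, a 2.1-fold lower number from compound 1 to compound 2 (0.31 log units; beyond the scatter), and it is modest. It swaps a whole ring, so it offers only a loose guide. A small move towards a higher number is therefore expected, probably within the scatter. The expected step is a 1.3-fold higher number from compound 2 to compound 3 (0.13 log units; within the scatter). For compound 3 the estimated value is 7000 nM, with an expected range of 3000 nM to 16000 nM.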

Compound 3, concentration for 50% growth inhibition: 6500 nM
The estimate for compound 3 lay 1.1-fold (0.03 log units) above the measured number; the measured number falls inside the stated range.
By their numbers in this assay, from the lowest: compounds 2, 3 and 1 (each within the scatter of the next, the first and the last beyond it).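

In this assay, hydrogen in place of methoxy gives a 1.3-fold higher number from compound 2 to compound 3 (0.10 log units; within the scatter), so at this aromatic carbon the two groups cannot be told apart. Phenyl in place of pyridin-2-yl gives a 1.6-fold lower number from compound 1 to compound 3 (0.22 log units; within the scatter), so unlike 4-methoxyphenyl, plain phenyl does not separate from pyridin-2-yl beyond the scatter. Nothing available explains these small steps. From the compounds shown here alone, it remains open whether a chlorine atom, a hydroxyl or an amine on this same carbon would move the number beyond the scatter.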